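A few compounds are considered here, and "the series" means these few. Any claim that something is new, unique, unknown or untested is made for them only; others in the source may bear on it.

Series notes. Compound 1 `Cn1nccc1-c1cc(C(F)(F)F)ccc1[C@H]1CCOc2cc(S(=O)(=O)Nc3ccncn3)ccc21` carries a pyrimidin-4-yl on the sulfonamide nitrogen; in a physicochemical assay for lipophilicity (on this read-out higher numbers stand for higher lipophilicity and lower numbers for lower lipophilicity), compound 1 gives 1.8. Compound 2 `Cn1nccc1-c1cc(C(F)(F)F)ccc1[C@H]1CCOc2cc(S(=O)(=O)Nc3nccs3)ccc21` carries a 1,3-thiazol-2-yl at that nitrogen instead, and in this assay compound 2 gives 2.2. The step between them is a number 0.40 log units higher from compound 1 to compound 2 (beyond the scatter). Within the data shown here, compound 2 therefore stands highest of the two numbers so far, with compound 1 as its only neighbour, lower by that step.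

Compound 3 `O=S(=O)(Nc1nccs1)c1ccc2c(c1)OCC[C@@H]2c1ccc(C(F)(F)F)cc1-c1nccs1` differs from compound 2 at another place: 1,3-thiazol-2-yl in place of 1-methyl-1H-pyrazol-5-yl on an aromatic carbon. Among the measured compounds shown here, no measured step covers this exchange; the one step on record, a number 0.40 log units higher from compound 1 to compound 2 (beyond the scatter), concerns the ring on the sulfonamide nitrogen, not the carbon-bound ring, and shows only that a 1,3-thiazol-2-yl entering the series went with a modest rise. On that slim basis a modest rise in this assay is expected, a number 0.50 log units higher from compound 2 to compound 3 (beyond the scatter). Compound 3 is estimated at 2.7, with a range from 2.3 to 3.1.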

Compound 3, distribution coefficient: 3.3
Beside the measured number, compound 3's estimate is 0.60 log units below it, and the stated range ends below it.
By their numbers in this assay, from the lowest: compound 1; then compound 2; then compound 3.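

Among these compounds, the carbon-bound ring at this position, ortho to a large group and meta to a trifluoromethyl group, moves the read-out in this assay more than the one change seen before. Here 1,3-thiazol-2-yl in place of 1-methyl-1H-pyrazol-5-yl gives a number 1.10 log units higher from compound 2 to compound 3 (beyond the scatter), a large step, against the modest a number 0.40 log units higher from compound 1 to compound 2 (beyond the scatter), and both rings are five-membered and aromatic with the same counts of donors and acceptors and no net charge. Nothing measured here accounts for the size of this step.

Going by these compounds, it remains open whether the same exchange on the aromatic carbon would give a step of this size with the pyrimidin-4-yl of compound 1 on the sulfonamide nitrogen. Also open, on these data alone, is how an amine or a carboxylic acid at this carbon would read in this assay.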